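Swapping chloro for methyl on the sulfonyl aryl of compound 1

This account rests on a few compounds, and the source may have more. Where it says the series, first, only, none or still open, it means among the compounds named here.

This account follows a single change made to compound 1, `Cc1cccc(-c2noc(C3CN(S(=O)(=O)c4ccc(Cl)cc4)C3)n2)c1`, within a small set of compounds sharing one core. In an assay on HEK293 cells for negative allosteric modulation of metabotropic glutamate receptor 5 (Homo sapiens), read by FLIPR (on this read-out lower numbers stand for stronger inhibition and higher numbers for weaker inhibition), compound 1 gives 1100 nM, the higher of the two numbers reported. Compound 2, `O=C(c1ccccc1F)N1CC[C@H]1c1nc(-c2cccc(F)c2)no1`, gives 920 nM in this assay, and the gap to compound 1 lies within the usual scatter, so no order between them can be read. Compound 3, `COC1CCN(C(=O)N2CC(c3nc(-c4cccc(Cl)c4)no3)C2)CC1`, returns only a limit in this assay, > 10000 nM; this is the limit of > 10000 nM in this assay, at which 1 of the 3 values shown sits, a boundary of the measurement and not a number.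

The compound yet to be measured is compound 4, `Cc1ccc(S(=O)(=O)N2CC(c3nc(-c4cccc(C)c4)no3)C2)cc1`. It differs from compound 1 in one place: methyl in place of chloro on an aromatic carbon. Among the measured compounds shown here, no measured pair in the set shows this exchange, so its size is not known from these data. Without such a step, the expected outcome in this assay is a change no larger than the scatter, with no clear direction, so that a 1.3-fold higher number from compound 1 to compound 4 (0.10 log units; within the scatter) is the estimated step. For compound 4 the estimate in this assay is therefore 1400 nM, expected to lie between 500 nM and 4500 nM.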

Compound 4, half-maximal inhibitory concentration: 670 nM
The estimate for compound 4 lay 2.1-fold (0.32 log units) above the measured number; measured number inside the range.
By their numbers in this assay, from the lowest: compounds 4, 2 and 1 (each within the scatter of the next). At a limit, above all of these: compound 3.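

Among the compounds shown here, the only measured pair in this set showing this exchange puts a number on it: 4-chlorophenyl to 4-methylphenyl, para to a large group, gives a 1.6-fold lower number from compound 1 to compound 4 (0.22 log units; within the scatter) in this assay. The two compounds therefore cannot be put in order, and at this position the read-out does not tell methyl from chloro. Nothing in the data shown bears on why the step has this size.

As far as these compounds go, what the position tolerates beyond these two groups stays open, since a single pair cannot say whether an amine, a hydroxyl or a carboxylic acid on the same aromatic carbon would keep a number of this size. For the compounds shown here, whether this exchange gives a like step on any other compound also remains unknown, since no second pair shows it.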